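A few compounds are considered here, and "the series" means these few. Any claim that something is new, unique, unknown or untested is made for them only; others in the source may bear on it.

Three compounds share one core and differ only in a single substituent on an aromatic carbon. Compound 1 `O=C(/C=C/c1ccccc1)NS(=O)(=O)c1ccccc1` gives 3.5 ug/mL in a functional assay on B16-F10 cells (Mus musculus) for antiproliferative activity, read by ELISA and MTT assay, with a stated time of 48 h; on this read-out lower numbers stand for stronger inhibition and higher numbers for weaker inhibition; compound 2 `O=C(/C=C/c1ccc(F)cc1)NS(=O)(=O)c1ccccc1` gives 2.1 ug/mL; compound 3 `COc1ccc(/C=C/C(=O)NS(=O)(=O)c2ccccc2)cc1` gives 13.2 ug/mL. Compound 3 thus stands highest of the three numbers, and two measured steps account for that: a 3.8-fold higher number from compound 1 to compound 3 (0.58 log units; beyond the scatter) and a 6.3-fold higher number from compound 2 to compound 3 (0.80 log units; beyond the scatter), both beyond the scatter. The remaining step, a 1.7-fold lower number from compound 1 to compound 2 (0.22 log units; within the scatter), lies within the scatter.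

Compound 4 `O=C(/C=C/c1ccc([N+](=O)[O-])cc1)NS(=O)(=O)c1ccccc1` has not yet been measured. It differs from compound 3 by nitro in place of methoxy on an aromatic carbon. Among the compounds with values here, the steps that bear on this change are the two in which methoxy entered, since they show that methoxy on this carbon raised the number by a modest amount; its removal would be expected to return the number toward where compound 1 and compound 2 sit. Within the data shown here, no measured step shows nitro on this carbon, so the nitro group itself is an unknown and widens the range.

Compound 4 is therefore expected to show a 3.8-fold lower number from compound 3 to compound 4 (0.58 log units; beyond the scatter). Compound 4 is estimated at 3.5 ug/mL, with a range from 1.5 ug/mL to 9 ug/mL.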

Compound 4, half-maximal inhibitory concentration: 4.8 ug/mL
Compound 4: the middle estimate sits 1.4-fold (0.14 log units) below what was measured, within the range that was stated.
By their numbers in this assay, from the lowest: compounds 2, 1 and 4 (each within the scatter of the next, the first and the last beyond it); then compound 3.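

Nitro on this carbon does not carry the rise that methoxy brought in this assay: the change gives a 2.8-fold lower number from compound 3 to compound 4 (0.44 log units; beyond the scatter), so the high number of compound 3 belongs to methoxy and not to every group placed here, and with 3 heavy atoms against 2 for methoxy, nitro shows that the heavy-atom count does not order these two groups. Against the unsubstituted core the change gives a 1.4-fold higher number from compound 1 to compound 4 (0.14 log units; within the scatter), which leaves nitro indistinguishable from hydrogen, while a 2.3-fold higher number from compound 2 to compound 4 (0.36 log units; beyond the scatter) separates nitro from fluoro, a difference that hydrogen and fluoro do not show between themselves. Nothing at hand gives a measured reason for the difference between these groups on this carbon.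

On these data alone, whether an amine or a carboxylic acid on this carbon would group with compound 1 and compound 4 or stand apart like compound 3 remains open. Also open, as far as these compounds go, is how any of these groups would behave elsewhere on the same ring, or whether a methyl or chloro group here would follow fluoro or nitro.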